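The compounds below may be only part of what the source reports. "The series", "measured", "known", "first", "only" and "open" are said of these compounds alone.

Compound 2 `Cc1oc2c([C@H]3CCN(C)C[C@H]3O)c(O)cc(O)c2c(=O)c1C(O)c1ccc([N+](=O)[O-])cc1` gives 5% in a functional assay on Caco-2 cells (Homo sapiens) for inhibition, read by MTT assay, with a stated time of 48 h, tested at 10 uM (a higher number here means more inhibition of growth at the concentration tested, a lower number less inhibition of growth), the lower of the two numbers seen so far; compound 1 `Cc1cc(=O)c2c(O)cc(OC/C=C/c3ccccc3)c([C@H]3CCN(C)C[C@H]3O)c2o1` gives 9%, and the gap between the two lies within the scatter. Compound 3 `Cc1oc2c([C@H]3CCN(C)C[C@H]3O)c(O)cc(O)c2c(=O)c1C(O)c1cccc(Cl)c1Cl` differs from compound 2 in one place: 2,3-dichlorophenyl in place of 4-nitrophenyl on a saturated chain carbon bound to an aromatic carbon and an oxygen on a saturated carbon. Among the measured compounds shown here, no step between measured compounds is available to anchor this change, so the step is expected to be small, a number 5 percentage points higher from compound 2 to compound 3 (within the scatter), not clearly beyond the scatter. Compound 3 is therefore estimated at 10% in this assay, with a range from 0% to 30%.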

Compound 3, percent growth inhibition at one concentration: 3%
Estimate against measurement, compound 3: 7 percentage points above, within the range that was stated.
By their numbers in this assay, from the lowest: compounds 3, 2 and 1 (each within the scatter of the next).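

In this assay, among the compounds shown here, 2,3-dichlorophenyl in place of 4-nitrophenyl on this saturated chain carbon gives a number 2 percentage points lower from compound 2 to compound 3 (within the scatter), the first step that can be read at this place. The two aryl groups, one with chlorine and one with nitro, therefore cannot be told apart here. Nothing shown bears on why this is so. Still open, from the compounds shown here alone, is whether a 4-aminophenyl group, or a plain methyl in place of the aryl ring, would move the number beyond the scatter.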